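The compounds below may be only part of what the source reports. "The series", "measured", "known", "first", "only" and "open" are said of these compounds alone.

The series shares one core and differs in the group on the carbonyl carbon. Compound 1 `CC(=O)OCc1ccc2oc(=O)c(C(=O)Oc3cccc(Br)c3)cc2c1` was tested in a functional assay on HT-1080 cells (Homo sapiens), read by transwell migration, with a stated time of 24 h, tested at 1 uM (a lower number here means a stronger effect, a higher number a weaker effect of the compound at the concentration tested), where compound 1 gives 21.8%. Compound 2 `CC(=O)OCc1ccc2oc(=O)c(C(=O)Sc3cccc(Br)c3)cc2c1` gives 70.9% in this assay, and compound 3 `CC(=O)OCc1ccc2oc(=O)c(C(=O)N(C)c3cccc(Cl)c3)cc2c1` gives 82.6%. Compound 1 stands lowest of the three numbers: the step to compound 2 is a number 49.1 percentage points higher from compound 1 to compound 2 (beyond the scatter), and the step to compound 3 is a number 60.8 percentage points higher from compound 1 to compound 3 (beyond the scatter). Between the two weaker compounds the step is a number 11.7 percentage points higher from compound 2 to compound 3 (beyond the scatter).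

Compound 4 `NCc1ccc2oc(=O)c(C(=O)Oc3cccc(Br)c3)cc2c1` has not yet been measured. It differs from compound 1 in one place: amino in place of acetoxy on a saturated chain carbon bound to an aromatic carbon. None of the three measured steps touches this part of the molecule; all of them concern the group on the carbonyl carbon, and the 3-bromophenoxy group of compound 1 is kept unchanged in compound 4. Among the compounds with values here, no measured step bears on this change, and the expectation rests on compound 1 alone. A step of a number 13.2 percentage points higher from compound 1 to compound 4 (beyond the scatter) is expected, with wide uncertainty that spans from no change beyond the scatter to a clear weakening. Compound 4 is estimated at 35% in this assay, within a range from 15% to 60%.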

Compound 4, a percentage reported as activity, at one concentration (the size of the read-out at that concentration, not a potency): 79.3%
Compound 4: the middle estimate sits 44.3 percentage points below what was measured; the measured number lies above the stated range.
By their numbers in this assay, from the lowest: compound 1; then compounds 2, 4 and 3 (each within the scatter of the next, the first and the last beyond it).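

In this assay the exchange of acetoxy for amino on a saturated chain carbon bound to an aromatic carbon gives a number 57.5 percentage points higher from compound 1 to compound 4 (beyond the scatter), while the 3-bromophenoxy group stays in place. The earlier steps, a number 49.1 percentage points higher from compound 1 to compound 2 (beyond the scatter) and a number 60.8 percentage points higher from compound 1 to compound 3 (beyond the scatter), had shown large changes only on the carbonyl carbon; this one shows that the low number of compound 1 does not rest on its 3-bromophenoxy group alone, since a change at the acetoxymethyl end of the molecule also produces a large step. Whether the step comes from losing the acetoxy group or from bringing in the amino group cannot be told from this one pair, and no measurement at hand offers an explanation for it.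

The compounds shown leave open whether a hydroxyl, an acetamide or a longer chain on the same carbon would keep the number near that of compound 1. They also leave open how the amino group would behave alongside the carbonyl groups of compound 2 and compound 3, both of which keep the acetoxy group.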